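Replacing a carbamoylamino link with benzamido on an inert scaffold

The source may hold more compounds than are shown below. What is called first, only, known or untested is meant among the compounds shown, and "the series" means these compounds.

Compound 1 `COc1cc(-c2nn(-c3cccc(NC(=O)Nc4ccc(Cl)c(Cl)c4)c3)cc2-c2ccncc2)ccc1Cl` gives > 50000 nM in a functional assay on Hs-578T cells (Homo sapiens) for inhibition, read by sulforhodamine B assay, with a stated time of 48 h (on this read-out lower numbers stand for stronger inhibition of growth and higher numbers for weaker inhibition of growth), a limit of the assay rather than a number.
Compound 2 `O=C(Nc1cccc(-n2cc(-c3ccncc3)c(-c3ccc(Cl)c(O)c3)n2)c1)Nc1ccc(Cl)c(Cl)c1` gives 3150 nM in this assay.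
Compound 3 `O=C(Nc1cccc(-n2cc(-c3ccncc3)c(-c3ccc(Cl)c(O)c3)n2)c1)Nc1cc(C(F)(F)F)cc(C(F)(F)F)c1` gives 4080 nM in this assay.

Compound 1 thus stands at the weak end of what has been seen: the limit of > 50000 nM in this assay, at which 1 of the 3 values shown sits, so only a limit is known for it. For the measured compounds named here, the one measured step, an at least 15-fold lower number from compound 1 to compound 2 (1.20 log units; beyond the scatter), concerns the methyl on the oxygen, a part that compound 4 keeps. Compound 4 `COc1cc(-c2nn(-c3cccc(NC(=O)c4ccccc4)c3)cc2-c2ccncc2)ccc1Cl` differs from compound 1 by phenyl in place of (3,4-dichlorophenyl)amino on a carbonyl carbon; read one bond further out, ((3,4-dichlorophenyl)carbamoyl)amino becomes benzamido. Going by the values given here, no measured step bears on this change. The step of a number no higher from compound 1 to compound 4 (the limit leaves the size open) is therefore expected to stay within the scatter, with compound 4 most likely again reported as a limit. Compound 4 is estimated at 50000 nM, between 15000 nM and 100000 nM.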

Compound 4, concentration for total growth inhibition: > 100000 nM
Compound 4 was reported as a limit; the forecaster's own chance of this, stated with the estimate: 70%; middle value at least 2.0-fold (0.30 log units) from the limit.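

In this assay compound 4 gives > 100000 nM, a limit of the assay. For the compounds shown here, compound 1 gives > 50000 nM, also a limit, so no step between compound 1 and compound 4 can be read. From the compounds shown here alone, what benzamido in place of ((3,4-dichlorophenyl)carbamoyl)amino does to growth inhibition stays open.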